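The source may report more compounds than this note shows. Statements on the series, on what has been measured and on what is new or still open speak of the compounds shown alone.

Compound 1, `Oc1ccccc1-c1cc(-c2cccc(C(F)(F)F)c2)cc(-c2ccccc2O)n1`, gives > 50000 nM in a functional assay on HCT-15 cells (Homo sapiens) for inhibition (a higher number here means a weaker inhibitor, a lower number a stronger inhibitor), a limit of the assay.
Compound 2, `Oc1ccccc1-c1cc(-c2ccc(C(F)(F)F)cc2)cc(-c2ccccc2O)n1`, gives > 50000 nM in this assay, again a limit.
Compound 3, `Oc1ccc(-c2cc(-c3cccc(C(F)(F)F)c3)cc(-c3ccccc3O)n2)cc1`, gives > 50000 nM in this assay, also a limit.

The change from compound 1 to compound 2 is 4-(trifluoromethyl)phenyl in place of 3-(trifluoromethyl)phenyl on an aromatic carbon. Its step, a step that the two limits leave unreadable from compound 1 to compound 2, cannot be sized, because of the limit of > 50000 nM in this assay, at which 3 of the 3 values shown sit. The cores of compound 1 and compound 3 differ by 4-hydroxyphenyl in place of 2-hydroxyphenyl on an aromatic carbon. Compound 4, `Oc1ccc(-c2cc(-c3ccc(C(F)(F)F)cc3)cc(-c3ccccc3O)n2)cc1`, carries the same kind of change as compound 2: 4-(trifluoromethyl)phenyl in place of 3-(trifluoromethyl)phenyl on an aromatic carbon. The surroundings differ, since in compound 2 the site is meta to two 2-hydroxyphenyl groups, whereas in compound 4 it is meta to a 2-hydroxyphenyl group and to a 4-hydroxyphenyl group. Compound 4 is expected to show a step that the limit leaves unreadable from compound 3 to compound 4 in this assay, resting on compound 3 giving > 50000 nM and on a step that the two limits leave unreadable from compound 1 to compound 2. Compound 4 is estimated at 100000 nM, between 30000 nM and 500000 nM.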

Compound 4, half-maximal inhibitory concentration: > 50000 nM
Compound 4 gave a limit, no number (the forecaster's own chance of this, stated with the estimate: 85%); the middle value does not contradict the limit.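

Compound 4 also gives only a limit, so neither its step from compound 3 nor its step from compound 2 can be read: the limit of > 50000 nM in this assay, at which 4 of the 4 values shown sit.

The compounds shown leave open whether either change affects inhibition in this assay at all.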